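Alkene to alkyne on the fluoropyridine-bearing side chain

The source may hold more compounds than are shown below. What is called first, only, known or untested is meant among the compounds shown, and "the series" means these compounds.

Compound 1 `Cc1ccc(-n2nccn2)c(C(=O)N2C[C@H](/C=C/c3ccc(F)cn3)CC[C@H]2C)c1` gives 3 nM in an assay on cells for binding affinity to Orexin receptor type 2 (Homo sapiens), read by radioligand binding (a higher number here means a weaker inhibitor, a lower number a stronger inhibitor), the lowest of the three measured numbers. Compound 3 `Cc1ccc(-n2nccn2)c(C(=O)N2C[C@H](C#Cc3cnccc3O)CC[C@H]2C)c1` gives 7.5 nM, and compound 2 `Cc1ccc(-n2nccn2)c(C(=O)N2C[C@H](C#Cc3ccc(CO)cn3)CC[C@H]2C)c1` gives 130 nM. Compound 4 `Cc1ccc(-n2nccn2)c(C(=O)N2C[C@H](C#Cc3ccc(F)cn3)CC[C@H]2C)c1` is the unmeasured neighbour of compound 1; the change is 2-(5-fluoropyridin-2-yl)ethynyl in place of 2-(5-fluoropyridin-2-yl)ethenyl on a saturated ring carbon. Among the measured compounds shown here, no measured step isolates this linker change alone. The two steps that bear on it each replace the ethenyl by an ethynyl while also changing the aromatic group: a 43-fold higher number from compound 1 to compound 2 (1.64 log units; beyond the scatter) and a 2.5-fold higher number from compound 1 to compound 3 (0.40 log units; beyond the scatter). Both alkyne compounds lie higher than compound 1, but the aryl change differs in each, so the share that belongs to the linker is not separable; the smaller of the two, the step to compound 3, bounds what a linker change alone might plausibly cost. Compound 4 is therefore expected to be a modest step weaker than compound 1, a 2.7-fold higher number from compound 1 to compound 4 (0.43 log units; beyond the scatter). Compound 4 is estimated at 8 nM in this assay, with a range from 3 nM to 25 nM.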

Compound 4, inhibition constant: 1.1 nM
Compound 4: the middle estimate sits 7.3-fold (0.86 log units) above what was measured; the measured number lies below the stated range.
By their numbers in this assay, from the lowest: compound 4; then compound 1; then compound 3; then compound 2.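

Taken alone, the linker change carries no cost in this assay and runs the other way, with a 2.7-fold lower number from compound 1 to compound 4 (0.44 log units; beyond the scatter) as the ethynyl replaces the ethenyl on the saturated ring carbon. With the ethynyl held constant, the aromatic end accounts for the higher numbers of the other two alkynes, giving a 6.8-fold lower number from compound 3 to compound 4 (0.83 log units; beyond the scatter) for the change of pyridine group and a 120-fold lower number from compound 2 to compound 4 (2.07 log units; beyond the scatter) for fluoro in place of hydroxymethyl, the largest step among these compounds. Nothing on hand explains either the linker step or the aromatic steps.

Going by these compounds, it remains open whether a chloro, methoxy or amino group in place of the fluoro would keep the number near that of compound 4. On these data alone, it is also open whether an ethyl linker would follow the ethynyl or the ethenyl, and whether the linker step holds with the hydroxymethylpyridine.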